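Working notes: chlorophenyl variants, compounds 2 and 3

This account rests on a few compounds, and the source may have more. Where it says the series, first, only, none or still open, it means among the compounds named here.

Measured so far:
compound 1, `Oc1ccccc1CNc1ccc(N2CCNCC2)cc1`: "not active" (no number reported)
compound 2, `Oc1ccccc1CNc1ccc(-c2cccc(Cl)c2)cc1`: 6200 nM

In a functional assay on Jurkat cells (Homo sapiens) for activation, with a stated time of 24 h (on this read-out lower numbers stand for an effect already at smaller amounts and higher numbers for an effect only at larger amounts of compound), compound 2 gives 6200 nM. Within the data shown here, this is the only number in the set so far. Compound 1 is reported in this assay as "not active" (no number reported), without a number. Compound 3, `Oc1ccccc1CNc1ccc(-c2ccccc2Cl)cc1`, differs from compound 2 by 2-chlorophenyl in place of 3-chlorophenyl on an aromatic carbon. Among the measured compounds shown here, no measured step of this kind exists, so size and direction are open; the expectation is a change of about the size of the scatter, leaning weaker, a 1.3-fold higher number from compound 2 to compound 3 (0.11 log units; within the scatter). Compound 3 is accordingly estimated at 8000 nM, with a range from 2500 nM to 25000 nM.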

Compound 3, half-maximal effective concentration: "not active" (no number reported)
Compound 3: no number reported, and the estimate cannot be compared.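

Among these compounds, compound 3 carries no number, so no step from compound 2 to compound 3 can be read. What the compounds shown leave open is how 2-chlorophenyl compares with 3-chlorophenyl in size of effect. No evidence bears on this result.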